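This account rests on a few compounds, and the source may have more. Where it says the series, first, only, none or still open, it means among the compounds named here.

Compound 1, `CN(CCCN1CCCCC1)c1ccc(C(=O)N2CCc3ccc(OS(N)(=O)=O)cc3C2)cc1`, is measured in an assay on HEK293 cells for inhibition of Steryl-sulfatase (Homo sapiens), tested at 1 uM (a lower number here means a weaker effect, a higher number a stronger effect of the compound at the concentration tested), and gives 40.7%, the highest of the three numbers recorded in that assay. Compound 3, `CCN(Cc1ccccc1)Cc1ccc(S(=O)(=O)N2CCc3ccc(OS(N)(=O)=O)cc3C2)cc1`, gives 31% in this assay, and that number lies within the usual scatter of the number for compound 1, so the two cannot be told apart. Compound 2, `NS(=O)(=O)Oc1ccc2c(c1)CN(C(=O)c1cccc(N3CCN(c4ncccn4)CC3)c1)CC2`, gives 24.4% in this assay, a number that lies beyond the scatter below compound 1.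

Compound 4, `CCN(Cc1ccncc1)c1ccc(C(=O)N2CCc3ccc(OS(N)(=O)=O)cc3C2)cc1`, has not yet been measured. Compared with compound 1 it shows one change: ethyl((pyridin-4-yl)methyl)amino in place of methyl(3-(piperidin-1-yl)propyl)amino on an aromatic carbon. The amide-linked core and the sulfamate are kept; only the amino group attached to the aromatic carbon is exchanged, a non-aromatic ring with one hetero atom leaving and an aromatic ring with one hetero atom entering.

Among the measured compounds shown here, no pair of measured compounds differing in one place exists in this set, so there is no direct precedent for the size of such a step. All three measured compounds fall in a fairly narrow band of inhibition, which suggests a step of modest size is expected, most likely a small fall or none beyond the scatter, estimated as a number 7.7 percentage points lower from compound 1 to compound 4 (within the scatter). Compound 4 is therefore expected to give about 33% in this assay, somewhere between 15% and 50%.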

Compound 4, a percentage reported as inhibition, at one concentration (the size of the read-out at that concentration, not a potency): 86.6%
The estimate for compound 4 lay 53.6 percentage points below the measured number, and the stated range ends below it.
By their numbers in this assay, from the lowest: compounds 2, 3 and 1 (each within the scatter of the next, the first and the last beyond it); then compound 4.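

Exchanging methyl(3-(piperidin-1-yl)propyl)amino for ethyl((pyridin-4-yl)methyl)amino on an aromatic carbon, para to a large group, gives a number 45.9 percentage points higher from compound 1 to compound 4 (beyond the scatter) in this assay. Among the compounds shown here, this is the first step in the set that can be read at a single place, and it shows that the read-out at this position depends strongly on which amino group is attached, even though the two groups have the same counts of hydrogen-bond donors and acceptors and neither carries a net charge. Nothing available here bears on why the exchange has an effect of this size.

As far as these compounds go, it remains open which part of the exchange carries the step, as the six-membered non-aromatic ring gives way to a six-membered aromatic ring while the chain and the other substituent on the amine nitrogen change with it. From the compounds shown here alone, it is also open whether a benzyl group or a pyridin-3-ylmethyl group in place of the pyridin-4-ylmethyl group, or a methyl group in place of the ethyl group, would keep the read-out of compound 4.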